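The source may hold more compounds than are shown below. What is called first, only, known or untested is meant among the compounds shown, and "the series" means these compounds.

The series is built on a cyclopropane bearing a trimethoxyphenyl group and an anilide, and it is examined in a functional assay on HeLa cells (Homo sapiens) for cytotoxicity, read by MTT assay, with a stated time of 48 h; a higher number here means a weaker inhibitor, a lower number a stronger inhibitor. Compound 1, `CCOC(=O)[C@]1(C(=O)Nc2ccccc2)C[C@H]1c1cc(OC)c(OC)c(OC)c1`, gives only a limit of the assay, > 100000 nM. Compound 2, `COc1cc([C@H]2C[C@@]2(CO)C(=O)Nc2ccccc2)cc(OC)c1OC`, in which the ester is replaced by a hydroxymethyl group, likewise gives only a limit, > 100000 nM. Compound 3, `CCOC(=O)[C@@]1(C(=O)NCc2ccc(C)cc2)C[C@@H]1c1cc(OC)c(OC)c(OC)c1`, with a 4-methylbenzyl amide, also gives only a limit, > 100000 nM. Compound 3 therefore stands where every measured compound stands: at the limit of > 100000 nM in this assay, at which 3 of the 3 values shown sit, so no compound can be ranked against another on the numbers shown.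

Compound 4, `CCOC(=O)[C@@]1(C(=O)Nc2ccccc2)C[C@@H]1c1cc(OC)c(OC)c(OC)c1`, is the next compound to be measured. It differs from compound 3 in one place: phenyl in place of 4-methylbenzyl on an amide-type nitrogen. Going by the values given here, no measured pair in this set shows what such a change does, and the three compounds give no hint of any activity within the range of this assay. With every measured value sitting at the same limit, the step from compound 3 to compound 4 is expected to be none beyond the scatter, a number no higher from compound 3 to compound 4 (the limit leaves the size open), and compound 4 is expected to return a value of about 100000 nM, most likely again only as a limit, within a range from 30000 nM to 300000 nM.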

Compound 4, half-maximal inhibitory concentration: > 100000 nM
Compound 4: no number, only a limit; the forecaster's own chance of this, stated with the estimate: 85%; the middle value sits exactly at the limit.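

Compound 4 again gives only a limit in this assay, so none of its steps to compound 1, compound 2 or compound 3 can be read: the limit of > 100000 nM in this assay, at which 4 of the 4 values shown sit. The compounds shown leave open whether the amide substituent, the ester or hydroxymethyl group, or the configuration as drawn has any bearing on the value in this assay, even for this pair: the fact that compounds 1 and 4 differ only in the configuration as drawn.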